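The source may report more compounds than this note shows. Statements on the series, on what has been measured and on what is new or still open speak of the compounds shown alone.

Measured compounds:
compound 1 `CNc1nc(-c2ccccc2)nc2c1nnn2Cc1ccccc1Cl` — 191000000 nM
compound 2 `Fc1ccccc1Cn1nnc2c(NC3CCCCC3)nc(-c3ccccc3)nc21` — 1150000 nM
compound 3 `OC1CCC(Nc2nc(-c3ccccc3)nc3c2nnn3Cc2ccccc2F)CC1` — 1850000 nM

In an assay on isolated protein for binding affinity to adenosine receptor A1 (Bos taurus) (on this read-out lower numbers stand for stronger inhibition and higher numbers for weaker inhibition), compound 3 stands second highest of the three numbers. Its nearest neighbour is compound 2, and the step of a 1.6-fold higher number from compound 2 to compound 3 (0.21 log units; within the scatter) lies within the scatter. Compound 1, which differs from compound 3 at the same nitrogen and also on the benzyl ring, gives a far higher number in this assay, beyond the scatter.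

Compound 4 `CCCNc1nc(-c2ccccc2)nc2c1nnn2Cc1ccccc1F` arises from compound 3 by propyl in place of 4-hydroxycyclohexyl on a nitrogen on an aromatic ring. Among the compounds with values here, no measured step covers this exchange: the one single-point step, from compound 2 to compound 3, concerns only the hydroxy group and is small. What the values show is that compound 2 and compound 3, both carrying a ring on that nitrogen, sit close together, while compound 1 sits far higher. Compound 4 is therefore expected to land between those values, the step of a 4.3-fold higher number from compound 3 to compound 4 (0.64 log units; beyond the scatter) being upward, with a wide range given the absence of a direct precedent. The estimate for compound 4 in this assay is 8000000 nM, within 1500000 nM to 60000000 nM.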

Compound 4, inhibition constant: 3200000 nM
For compound 4 the middle estimate is 2.5-fold (0.40 log units) above the measured one, within the range that was stated.
By their numbers in this assay, from the lowest: compounds 2, 3 and 4 (each within the scatter of the next, the first and the last beyond it); then compound 1.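

In this assay the exchange at this nitrogen proves less demanding than a ring on it might have suggested: a 1.7-fold higher number from compound 3 to compound 4 (0.24 log units; within the scatter) is a step that separates the open propyl chain from the 4-hydroxycyclohexyl group by no more than the usual variation between repeats. Against the plain cyclohexyl group the exchange does register, though only modestly, with a 2.8-fold higher number from compound 2 to compound 4 (0.44 log units; beyond the scatter) as the printed step. Taken together, these two steps show that on this nitrogen, across these three compounds, the ring can give way to a short chain with no large shift in the number. What the compounds shown leave open is how a longer chain such as butyl, or a propyl chain ending in an amine or a carboxylic acid, would read at this nitrogen. No supporting data accompany these results, so the reason for these small steps remains unexplained.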